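The source may report more compounds than this note shows. Statements on the series, on what has been measured and on what is new or still open speak of the compounds shown alone.

Measured in a physicochemical assay for lipophilicity, read by HPLC, measured as chromatographic lipophilicity, at pH 7.4; a lower number here means a more polar compound, a higher number a more lipophilic compound:
- Compound 1 `CC(C)(C)C(=O)N1N=CCC1c1cc[nH]n1`: 2.7
- Compound 2 `CC(C)(C)C(=O)N1N=CCC1c1cocn1`: 3

Compound 2 stands at 3, and compound 1, at 2.7, lies within the scatter of it. Compound 3 `CC(C)(C)C(=O)N1N=CCC1c1c[nH]cn1` has not yet been measured. It differs from compound 2 by one change, (1H-imidazol-4-yl in place of 1,3-oxazol-4-yl on a saturated ring carbon), with 1H-imidazol-4-yl entering on a saturated ring carbon. Within the data shown here, only one measured step bears on this, since it also concerns the 1,3-oxazol-4-yl: a number 0.30 log units higher from compound 1 to compound 2 (within the scatter). Among the measured compounds shown here, no measurement yet exists for the 1H-imidazol-4-yl itself, so this step offers only weak guidance. A modest fall in this assay is nevertheless expected, somewhat larger than that step, and the estimated change is a number 0.50 log units lower from compound 2 to compound 3 (beyond the scatter). For compound 3 the estimated value is 2.5, with an expected range of 2 to 3.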

Compound 3, distribution coefficient: 1.7
Estimate against measurement, compound 3: 0.80 log units above, outside the stated range (below it).
By their numbers in this assay, from the lowest: compound 3; then compounds 1 and 2 (each within the scatter of the next).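

In this assay the 1H-imidazol-4-yl in place of 1,3-oxazol-4-yl gives a number 1.30 log units lower from compound 2 to compound 3 (beyond the scatter) on this saturated ring carbon, so this position can separate two five-membered aromatic rings of equal heavy-atom count, which the earlier pair, lying within the scatter, had not shown. Against the 1H-pyrazol-3-yl the same group gives a number 1.00 log units lower from compound 1 to compound 3 (beyond the scatter) and thus sets compound 3 apart from both earlier compounds, not from compound 2 alone. The leaving and entering groups differ in their counted hydrogen-bond donors and acceptors, but nothing measured here accounts for the size of these steps.

The compounds shown leave open whether the low reading of compound 3 would persist with a methyl group on the ring nitrogen of the 1H-imidazol-4-yl. They also leave open how an amine or a carboxylic acid on this ring carbon would read in this assay against these three heteroaromatic rings.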